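The compounds below may be only part of what the source reports. "The series", "measured", "known", "first", "only" and "open" are said of these compounds alone.

In a physicochemical assay for lipophilicity, at pH 7.4 (a higher number here means a more lipophilic compound, a lower number a more polar compound), three compounds sharing one core have been measured. Compound 1 `CNC(=O)c1cc(C(=O)N[C@H]2[C@@H]3COC[C@@H]32)cc2c1OC[C@H]2c1cccnc1` gives 1.4, compound 2 `CNC(=O)c1cc(C(=O)N[C@H]2[C@@H]3COC[C@@H]32)cc2c1OC[C@H]2c1cccc2[nH]ccc12` gives 3.1, and compound 3 `CNC(=O)c1cc(C(=O)N[C@H]2[C@@H]3COC[C@@H]32)cc2c1OC[C@H]2c1ccncc1` gives 1.3. Compound 3 therefore sits at the low end of these numbers, level with compound 1 within the scatter and well under compound 2.

Compound 4 `CNC(=O)c1cc(C(=O)N[C@H]2[C@@H]3COC[C@@H]32)cc2c1OC[C@H]2c1ccccc1C` keeps the shared core and differs from compound 3 in one place: 2-methylphenyl in place of pyridin-4-yl on a saturated ring carbon. This puts 2-methylphenyl in place of pyridin-4-yl on a saturated ring carbon. Within the data shown here, no measured compound carries 2-methylphenyl, so the evidence is indirect.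

Among the measured compounds shown here, three measured steps bear on the change. The exchange between the two pyridinyl groups is small, a number 0.10 log units lower from compound 1 to compound 3 (within the scatter), whereas the steps involving 1H-indol-4-yl are large, a number 1.70 log units higher from compound 1 to compound 2 (beyond the scatter) and a number 1.80 log units lower from compound 2 to compound 3 (beyond the scatter). Going by the size of those two large steps, a large rise in this assay is expected rather than a change within the scatter. The estimated step is a number 1.60 log units higher from compound 3 to compound 4 (beyond the scatter). Compound 4 is expected at 2.9, with an estimated range from 2.4 to 3.4.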

Compound 4, distribution coefficient: 4
Compound 4: middle estimate off by 1.10 log units, on the low side, outside the stated range (above it).
By their numbers in this assay, from the lowest: compounds 3 and 1 (each within the scatter of the next); then compound 2; then compound 4.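

In this assay, among these compounds, 2-methylphenyl on this saturated ring carbon gives the largest steps seen at the position so far (a number 2.70 log units higher from compound 3 to compound 4 (beyond the scatter) and a number 2.60 log units higher from compound 1 to compound 4 (beyond the scatter)). It also exceeds the group that had stood highest (a number 0.90 log units higher from compound 2 to compound 4 (beyond the scatter)), so the top number among these compounds now belongs to a single six-membered aromatic ring of carbon only, not to 1H-indol-4-yl. Nothing available accounts for the size of these steps.

Where a plain phenyl would stand remains open, so the methyl group's share of the step cannot be separated from that of replacing the pyridine ring with a ring of carbon only. Also open, on these data alone, is where the number would lie with a carboxylic acid or an amine on that aromatic ring.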